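Boronic acid for trifluoroethoxy in a dibromophenyl hydrazide

A few compounds are considered here, and "the series" means these few. Any claim that something is new, unique, unknown or untested is made for them only; others in the source may bear on it.

Compound 1 `O=C(NNc1c(Br)cccc1Br)c1ccc(OCC(F)(F)F)cc1` was tested in a toxicity assay on MDCK cells (Canis lupus familiaris) for cytotoxicity, read by CCK-8 assay, with a stated time of 48 h; on this read-out higher numbers stand for lower toxicity in this test and lower numbers for higher toxicity in this test. Compound 1 gives > 100000 nM, which is a limit of the assay and not a number. Compound 2 `O=C(NNc1c(Br)cccc1Br)c1ccc2ncccc2c1` gives > 100000 nM in this assay, again a limit. Compound 3 `CCc1ccc(C(=O)NNc2c(Br)cc(Br)cc2Br)cc1` gives > 100000 nM in this assay, also a limit. Compound 1 therefore stands at the same point as every other value known here, since (the limit of > 100000 nM in this assay, at which 3 of the 3 values shown sit); none of the three compounds shows measurable toxicity in this test.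

Compound 4 `O=C(NNc1c(Br)cccc1Br)c1ccc(B(O)O)cc1` is not yet measured in this assay. It differs from compound 1 as follows: a group of 3 heavy atoms (1 boron, 2 oxygen; no ring) in place of a group of 6 heavy atoms (2 carbon, 1 oxygen, 3 fluorine; no ring), on an aromatic carbon. Within the data shown here, no measured pair isolates this change, so the step can only be judged from the fact that all known values sit at the limit. Compound 4 is expected to stay at that limit, with a step of a number no higher from compound 1 to compound 4 (the limit leaves the size open) beyond the scatter not foreseen. The estimate for compound 4 in this assay is 100000 nM, within a range from 50000 nM to 300000 nM.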

Compound 4, half-maximal cytotoxic concentration: > 100000 nM
Compound 4: a limit, no number; the forecaster's own chance of this, stated with the estimate: 80%; the middle value lies on the limit itself.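

In this assay compound 1 and compound 4 both sit at a limit and give no number, so no step between them can be read: the limit of > 100000 nM in this assay, at which 4 of the 4 values shown sit.

The compounds shown leave open at what concentration any of them becomes toxic in this assay, and whether replacing 2,2,2-trifluoroethoxy changes that concentration.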